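A new ring group on the sulfur

This account rests on a few compounds, and the source may have more. Where it says the series, first, only, none or still open, it means among the compounds named here.

In a physicochemical assay for lipophilicity (on this read-out lower numbers stand for lower lipophilicity and higher numbers for higher lipophilicity), compound 2 `CCCCCCN(CCCCCSc1nc2ccccc2s1)C(=O)Nc1ccc(F)cc1F` stands highest at 7.78, while compound 1 `CCCCCCN(CCCCCSc1nc2ccccc2o1)C(=O)Nc1ccc(F)cc1F` gives 7.18. The unmeasured compound 3 `CCCCCCN(CCCCCSc1nc2c([nH]1)CCCC2)C(=O)Nc1ccc(F)cc1F` differs from compound 2 in one place, on a sulfur: a group of 9 heavy atoms (7 carbon, 2 nitrogen; one five-membered aromatic ring with 2 hetero atoms, one six-membered non-aromatic ring of carbon only) in place of a group of 9 heavy atoms (7 carbon, 1 nitrogen, 1 sulfur; one five-membered aromatic ring with 2 hetero atoms, one six-membered aromatic ring of carbon only), on a sulfur. Among the compounds with values here, the only measured step that bears on this is a number 0.60 log units higher from compound 1 to compound 2 (beyond the scatter), where 1,3-benzothiazol-2-yl came in place of 1,3-benzoxazol-2-yl. That same 1,3-benzothiazol-2-yl now leaves, so a fall of similar size in this assay is expected, though a single step is thin evidence. The estimated change is a number 0.78 log units lower from compound 2 to compound 3 (beyond the scatter). For compound 3 the estimate is 7, with an expected range of 6.4 to 7.6.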

Compound 3, partition coefficient: 6.81
Estimate against measurement, compound 3: 0.19 log units above; measured number inside the range.
By their numbers in this assay, from the lowest: compound 3; then compound 1; then compound 2.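

In this assay, the group on the sulfur with a six-membered non-aromatic carbon ring and a hydrogen-bond donor sits below both groups with a six-membered aromatic ring, at a number 0.97 log units lower from compound 2 to compound 3 (beyond the scatter) and at a number 0.37 log units lower from compound 1 to compound 3 (beyond the scatter) in the second comparison. Within the data shown here, this position therefore spans a wider range than the single earlier step showed. Nothing available explains the fall.

On these data alone, compound 3 changes the ring and the donor count together, so their shares remain open. A 1H-benzimidazol-2-yl group on the same sulfur would separate them.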